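From methylsulfanyl to ((tert-butyl)carbonyl)oxy on the shared core

This account rests on a few compounds, and the source may have more. Where it says the series, first, only, none or still open, it means among the compounds named here.

Three measured compounds share one core. Compound 1 `Cc1nc2c(CSc3ccccc3)cccn2c1C` gives 29% in a functional assay on the whole organism with Rattus norvegicus as the target, with a stated time of 4 h, at a dose of 40 mg/kg by the intraperitoneal route; on this read-out lower numbers stand for less inhibition and higher numbers for more inhibition at the one dose given (going by the name of the read-out). Compound 2 `CSCc1c(C)nc2c(OCc3ccccc3)cccn12` gives 29% in this assay, level with compound 1 at the digits shown, and compound 3 `COC(=O)Cc1c(C)nc2c(OCc3ccccc3)cccn12` gives 23% in this assay. Within the data shown here, the one measured step that bears on the change in hand, a number 6 percentage points lower from compound 2 to compound 3 (within the scatter), lies within the scatter. Compound 4 `Cc1nc2c(OCc3ccccc3)cccn2c1COC(=O)C(C)(C)C` differs from compound 2 by ((tert-butyl)carbonyl)oxy in place of methylsulfanyl on a saturated chain carbon bound to an aromatic carbon. Among the measured compounds shown here, that single step is the only guide, and it suggests the read-out stays roughly where it is, with nothing pointing to a move beyond the scatter. For compound 4 the expected step is a number 2 percentage points lower from compound 2 to compound 4 (within the scatter). The estimate for compound 4 is 27%, between 14% and 40%.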

Compound 4, a percentage reported as inhibition, in the whole organism at one dose (the size of the read-out at that dose, not a potency): 48%
Compound 4: middle estimate off by 21 percentage points, on the low side; measured number outside the range, above it.
By their numbers in this assay, from the lowest: compounds 3, 1 and 2 (each within the scatter of the next); then compound 4.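

In this assay, the result shows that the group on a saturated chain carbon bound to an aromatic carbon can move the read-out beyond the scatter: ((tert-butyl)carbonyl)oxy gives a number 19 percentage points higher from compound 2 to compound 4 (beyond the scatter) and a number 25 percentage points higher from compound 3 to compound 4 (beyond the scatter). The earlier step from methylsulfanyl to methoxycarbonyl had shown no such move. No measurement shown here accounts for the rise.

The compounds shown leave open whether the tert-butyl part is needed for this level, or whether acetyloxy would match it. As far as these compounds go, how hydroxy or an amine would read at this place also remains open.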